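The source may report more compounds than this note shows. Statements on the series, on what has been measured and on what is new or still open speak of the compounds shown alone.

Values in a functional assay on HeLa cells (Homo sapiens) for cytotoxicity, read by MTT assay, with a stated time of 24 h (a lower number here means a stronger inhibitor, a higher number a weaker inhibitor), for the series so far

- compound 1 `CN1C/C(=C\c2cccc([N+](=O)[O-])c2)C(=O)/C(=C/c2ccccc2F)C1` gives 2340 nM
- compound 2 `COc1cc(/C=C2\CN(C)C/C(=C\c3ccc(C#N)cc3)C2=O)cc(OC)c1` gives 3420 nM
- compound 3 `COc1cc(/C=C2\CN(C)C/C(=C\c3ccc(Cl)cc3Cl)C2=O)cc(OC)c1OC` gives > 20000 nM as a limit of the assay, not a number

Going by the values given here, compound 1 holds one of only two numbers. Compound 1 at 2340 nM and compound 2 at 3420 nM lie within the scatter of each other.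

Next in this assay is compound 4 `CN1C/C(=C\c2cccc(Br)c2)C(=O)/C(=C/c2cccc([N+](=O)[O-])c2)C1` with 3-bromophenyl in place of 2-fluorophenyl on a double-bonded chain carbon bound to a double-bonded ring carbon in the structure of compound 1.

Among the compounds with values here, no measured pair isolates this change, so its size cannot be read directly. Within the data shown here, the only guide is the level shared by compound 1 at 2340 nM and compound 2 at 3420 nM and so no step beyond the scatter is expected, in either direction. The estimated step of a 1.1-fold higher number from compound 1 to compound 4 (0.03 log units; within the scatter) is expected to be small. Compound 3 reaches only the limit of > 20000 nM and so the expected range is kept wide on the upper side. For compound 4 the estimated value is 2500 nM with an expected range of 800 nM to 9000 nM in this series.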

Compound 4, half-maximal inhibitory concentration: 11100 nM
Compound 4: the middle estimate sits 4.4-fold (0.65 log units) below what was measured, and the stated range ends below it.
By their numbers in this assay, from the lowest: compounds 1 and 2 (each within the scatter of the next); then compound 4. At a limit, above all of these: compound 3.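

In this assay, going by these compounds alone, replacing 2-fluorophenyl with 3-bromophenyl on a double-bonded chain carbon bound to a double-bonded ring carbon gives a 4.7-fold higher number from compound 1 to compound 4 (0.68 log units; beyond the scatter), the first single-place step. Within the data shown here, compounds 1, 2 and 3 offered no pair that isolated one change, so this is the first direct sign that the group at this place affects the read-out in this assay, here by a modest step beyond the scatter. Nothing shown gives a cause for this step.

Since the halogen and its ring position change together, the compounds shown cannot separate the effect of bromine from that of the 3-position. As far as these compounds go, how an amine or a carboxylic acid on this phenyl ring, or a longer chain at this place, would read remains open.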